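This account rests on a few compounds, and the source may have more. Where it says the series, first, only, none or still open, it means among the compounds named here.

Measured compounds in a toxicity assay on MCF-10A cells (Homo sapiens) for cytotoxicity, read by MTT assay, with a stated time of 48 h; on this read-out higher numbers stand for weaker inhibition and lower numbers for stronger inhibition:
compound 1 `O=C(/C=C/c1ccc2c(c1)B(O)OC2)c1cccs1` gives 13800 nM
compound 2 `O=C(/C=C/c1ccc2c(c1)B(O)OC2)c1ccc(Br)cc1` gives 27800 nM
compound 3 `O=C(/C=C/c1ccc2c(c1)B(O)OC2)c1ccc(C(F)(F)F)cc1` gives 22300 nM

Compound 2 carries the largest of the three numbers, but the step of a 1.2-fold lower number from compound 2 to compound 3 (0.10 log units; within the scatter) and the step of a 2.0-fold higher number from compound 1 to compound 2 (0.30 log units; within the scatter) both fall within the scatter, so no ordering among the three compounds is claimed on this read-out.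

Compound 4 `O=C(/C=C/c1ccc2c(c1)B(O)OC2)c1ccc([N+](=O)[O-])cc1` is not yet measured. Against compound 2 the change is nitro in place of bromo on an aromatic carbon. The measured step bearing most directly on it is a 1.2-fold lower number from compound 2 to compound 3 (0.10 log units; within the scatter), a swap of one group for another on the same aromatic carbon, which stayed within the scatter; the step of a 2.0-fold higher number from compound 1 to compound 2 (0.30 log units; within the scatter), a change of the whole aryl group on the carbonyl carbon, also stayed within the scatter. Going by the values given here, no step so far moves the number beyond the scatter, so for compound 4 in this assay the expected step is a 1.1-fold lower number from compound 2 to compound 4 (0.05 log units; within the scatter), not beyond the scatter. The estimate for compound 4 is 25000 nM, with a range from 11000 nM to 55000 nM.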

Compound 4, half-maximal inhibitory concentration: 17500 nM
Estimate against measurement, compound 4: 1.4-fold (0.15 log units) above; measured number inside the range.
By their numbers in this assay, from the lowest: compounds 1, 4, 3 and 2 (each within the scatter of the next).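

In this assay the aromatic carbon para to a large group now has a third group to compare: nitro in place of bromo gives a 1.6-fold lower number from compound 2 to compound 4 (0.20 log units; within the scatter) and nitro in place of trifluoromethyl gives a 1.3-fold lower number from compound 3 to compound 4 (0.11 log units; within the scatter) on the same carbon. Nitro enters with more heavy atoms than bromo and with hydrogen-bond acceptors that bromo lacks, yet bromo, trifluoromethyl and nitro at this carbon remain within the scatter of one another, so no preference among these three groups can be read. No supporting measurement bears on this result.

As far as these compounds go, whether an amine, a carboxylic acid or a hydroxyl group on this carbon would also stay within the scatter remains open. Also open, from the compounds shown here alone, is how any of these groups would read on a different carbon of the ring.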